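Arylsulfanyl swap on the shared core: outlook for compound 3

A few compounds are considered here, and "the series" means these few. Any claim that something is new, unique, unknown or untested is made for them only; others in the source may bear on it.

Measured so far:
compound 1 `Nc1cc(N)c2nc(-c3ccccc3)c(Sc3ccc(F)cc3)nc2c1`: 38900 nM
compound 2 `COc1cc(CNc2nc3cc(N)cc(N)c3nc2-c2ccccc2)cc(OC)c1OC`: 14100 nM

Both numbers come from a functional assay on SF-268 cells (Homo sapiens) for inhibition, read by sulforhodamine B assay, with a stated time of 48 h; a lower number here means a stronger inhibitor of growth, a higher number a weaker inhibitor of growth. Compound 1 gives 38900 nM, the highest of the two numbers. Compound 2, the only comparator, gives 14100 nM, a lower number than compound 1 by a margin beyond the usual scatter. Going by the values given here, compound 1 and compound 2 differ at more than one place, so no single step between measured compounds is available, and nothing measured shows how a change on the sulfur alone shifts the result.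

Compound 3 `Nc1cc(N)c2nc(-c3ccccc3)c(Sc3ccc(Cl)c(Cl)c3)nc2c1` is the next compound for this assay. Relative to compound 1 it carries 3,4-dichlorophenyl in place of 4-fluorophenyl on a sulfur. The shared core and all other groups are unchanged. With no measured step of this kind in the series, the expectation rests on compound 1 alone, and a step of modest size is expected, most likely toward a lower number, but possibly not beyond the scatter.

The expected step of a 1.8-fold lower number from compound 1 to compound 3 (0.25 log units; within the scatter) is estimated as small and downward. Compound 3 is expected to give about 22000 nM, within a range of 8000 nM to 60000 nM.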

Compound 3, concentration for total growth inhibition: 51300 nM
The estimate for compound 3 lay 2.3-fold (0.37 log units) below the measured number; the range from low to high includes it.
By their numbers in this assay, from the lowest: compound 2; then compounds 1 and 3 (each within the scatter of the next).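

In this assay, the sulfur position now has its first step that changes one place only: 3,4-dichlorophenyl in place of 4-fluorophenyl gives a 1.3-fold higher number from compound 1 to compound 3 (0.12 log units; within the scatter). This step does not separate the two compounds, so the change from (4-fluorophenyl)sulfanyl to (3,4-dichlorophenyl)sulfanyl, with the shared core and all other groups held constant, leaves the read-out at one level within the scatter. The result is a single pair and sets no trend for this position, and no evidence is available to explain the outcome.

Still open, as far as these compounds go, is whether any group on this sulfur can move the number beyond the scatter, for example an unsubstituted phenyl, a phenyl ring carrying a carboxylic acid or a morpholine, or a simple ethyl chain in place of the aryl ring. Also open, from the compounds shown here alone, is whether the two chlorine atoms contribute separately, which would take the 3-chlorophenyl and 4-chlorophenyl groups on the same sulfur to read, each as a one-place comparison with compound 3.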